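From benzyl to cyclohexyl: a step expected to stay flat

A few compounds are considered here, and "the series" means these few. Any claim that something is new, unique, unknown or untested is made for them only; others in the source may bear on it.

Among the measured compounds shown here, compound 2 `Cc1cc(C)n(-c2ccc(S(=O)(=O)NC(=S)NCc3ccccc3)cc2)n1` holds the only plain number in a functional assay on the whole organism (blood, strain albino) with Mus musculus as the target, with stated times of 6 days and 4 h, at a dose of 0.4 mmol/kg by the oral route (a lower number here means less inhibition, a higher number more inhibition at the dose given (going by the name of the read-out)), where compound 2 gives 0%. Compound 1 `Cc1cc(C(=O)O)nn1-c1ccc(S(=O)(=O)NC(=S)NCc2ccccc2)cc1` gives < 2% in this assay, which is a limit rather than a number. The step that the limit leaves unreadable from compound 1 to compound 2 therefore cannot be sized, as the record the limit of < 2% in this assay, at which 1 of the 2 values shown sits, shows. Compound 3 `Cc1cc(C)n(-c2ccc(S(=O)(=O)NC(=S)NC3CCCCC3)cc2)n1` differs from compound 2 by cyclohexyl in place of benzyl on an amide-type nitrogen. For the measured compounds named here, no measured step involves this change, so nothing here points to a shift in either direction. In this assay the expected step is a number 2 percentage points higher from compound 2 to compound 3 (within the scatter), none beyond the usual scatter. Compound 3 is estimated at 2%, with a range from 0% to 12%.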

Compound 3, a percentage reported as inhibition, in the whole organism at one dose (the size of the read-out at that dose, not a potency): < 2%
Compound 3: no number, only a limit; the forecaster's own chance of this, stated with the estimate: 40%; the middle value lies on the limit itself.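

Among the compounds shown here, compound 3 gives only a limit and not a number, so no step from compound 2 to compound 3 can be read: the limit of < 2% in this assay, at which 2 of the 3 values shown sit.

Whether cyclohexyl and benzyl differ at all in this assay remains open, as does whether any of these compounds gives clear inhibition there.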